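Chloro in Place of Fluoro: The Next Halogen Step

This account rests on a few compounds, and the source may have more. Where it says the series, first, only, none or still open, it means among the compounds named here.

Of the compounds shown here, two have so far been measured in a functional assay on cells for positive allosteric modulation of metabotropic glutamate receptor 2 (Homo sapiens), read by fluorescence and calcium flux, with a stated time of 30 min; on this read-out higher numbers stand for an effect only at larger amounts of compound and lower numbers for an effect already at smaller amounts. Compound 1 `Brc1cccc2c1nnn2Cc1ccccc1` gives 80 nM in this assay . For the measured compounds named here, compound 2 `Fc1ccc(Cn2nnc3c(Br)cccc32)cc1` gives 15 nM and stands lowest of the two numbers; the one step connecting them, a 5.3-fold lower number from compound 1 to compound 2 (0.73 log units; beyond the scatter), puts fluoro in place of hydrogen on an aromatic carbon. Compound 3 `Clc1ccc(Cn2nnc3c(Br)cccc32)cc1` has not yet been measured. It differs from compound 2 by chloro in place of fluoro on an aromatic carbon. Going by the values given here, no measured step involves a chloro group, so the step from compound 1 to compound 2 is the only point of reference, and it speaks to adding a halogen rather than to exchanging one halogen for another. Fluoro at this place has gone together with a clearly lower number, and chloro is expected to do at least as much, with little further movement. Compound 3 is therefore estimated at 12 nM, with a range from 4 nM to 40 nM, meaning an expected step of a 1.3-fold lower number from compound 2 to compound 3 (0.10 log units; within the scatter) that stays within the scatter.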

Compound 3, half-maximal effective concentration: 17 nM
The estimate for compound 3 lay 1.4-fold (0.15 log units) below the measured number; low and high end bracket the measured number.
By their numbers in this assay, from the lowest: compounds 2 and 3 (each within the scatter of the next); then compound 1.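

In this assay, exchanging one halogen for the other on an aromatic carbon para to a large group does not separate the two compounds: the step is a 1.1-fold higher number from compound 2 to compound 3 (0.05 log units; within the scatter). Measured against hydrogen at this place, chloro gives a 4.7-fold lower number from compound 1 to compound 3 (0.67 log units; beyond the scatter), which stands alongside the earlier 5.3-fold lower number from compound 1 to compound 2 (0.73 log units; beyond the scatter), so both halogens go with a lower number than hydrogen, while these compounds cannot tell fluoro and chloro apart. Nothing available explains either the difference from hydrogen or the absence of a difference between the two halogens.

What the compounds leave open is how far this tolerance at the same place extends, for instance to a methoxy group, a trifluoromethyl group, a nitrile or an amine. From the compounds shown here alone, all three compounds also carry the same bromo group on the shared core, so what a methyl group, a nitrile or plain hydrogen would do there, and whether the halogen step would hold alongside such a change, remains open as well.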